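A para fluorine on the phenyl of compound 3

A few compounds are considered here, and "the series" means these few. Any claim that something is new, unique, unknown or untested is made for them only; others in the source may bear on it.

Of the compounds shown here, three on one shared core have been measured in a functional assay on HeLa cells (Homo sapiens) for inhibition, read by CCK-8 assay, with a stated time of 48 h; a higher number here means a weaker inhibitor, a lower number a stronger inhibitor. Compound 1 `COc1ccc(-c2cc3nccc(-c4cc(OC)c(OC)c(OC)c4)n3n2)cc1N` gives 283 nM. Compound 2 `COc1ccc(-c2cc3nccc(-c4cc(OC)c(OC)c(OC)c4)n3n2)cc1F` gives 236 nM in this assay. Compound 3 `COc1cc(-c2ccnc3cc(-c4ccccc4)nn23)cc(OC)c1OC` gives 458 nM in this assay; this is the highest of the three numbers, but the steps of a 1.6-fold higher number from compound 1 to compound 3 (0.21 log units; within the scatter) and a 1.9-fold higher number from compound 2 to compound 3 (0.29 log units; within the scatter) both lie within the scatter, so the three compounds stand level.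

Compound 4 `COc1cc(-c2ccnc3cc(-c4ccc(F)cc4)nn23)cc(OC)c1OC` has not yet been measured. It differs from compound 3 by fluoro in place of hydrogen on an aromatic carbon, the fluorine entering on an aromatic carbon of the six-membered carbon-only ring, para to a large group. Going by the values given here, two measured steps bear on this. Exchanging amino for fluoro on an aromatic carbon, a 1.2-fold lower number from compound 1 to compound 2 (0.08 log units; within the scatter), stayed within the scatter. Going from 3-fluoro-4-methoxyphenyl to plain phenyl, a 1.9-fold higher number from compound 2 to compound 3 (0.29 log units; within the scatter), also stayed within the scatter. Among the compounds with values here, no measured step places a single fluorine on an otherwise bare phenyl. The step of a 1.3-fold lower number from compound 3 to compound 4 (0.12 log units; within the scatter) is therefore expected to remain within the scatter, leaning if anything toward a slightly lower number. Compound 4 is expected to give about 350 nM, within a range from 150 nM to 900 nM.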

Compound 4, half-maximal inhibitory concentration: 5840 nM
Beside the measured number, compound 4's estimate is 17-fold (1.22 log units) below it; measured number outside the range, above it.
By their numbers in this assay, from the lowest: compounds 2, 1 and 3 (each within the scatter of the next); then compound 4.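

In this assay, going by these compounds alone, the phenyl of compound 3 proved far from indifferent to a single added atom: fluoro in place of hydrogen, para to a large group, gave a 13-fold higher number from compound 3 to compound 4 (1.11 log units; beyond the scatter) and so went beyond the scatter, whereas every step among the earlier compounds had stayed within it. The other two comparisons point the same way, with a 25-fold higher number from compound 2 to compound 4 (1.39 log units; beyond the scatter) and a 21-fold higher number from compound 1 to compound 4 (1.31 log units; beyond the scatter) as well, so 4-fluorophenyl stands apart from plain phenyl, 3-fluoro-4-methoxyphenyl and 3-amino-4-methoxyphenyl, and the tolerance seen across those three does not extend to every change on this ring. Nothing measured here accounts for this jump.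

From the compounds shown here alone, whether the jump belongs to fluorine itself or would follow any group on that carbon remains open, and a chloro, methyl or hydroxyl group there would separate those readings. It is also open whether the amino group of compound 1 or the fluoro of compound 2 plays any part in keeping those two numbers low, since the methoxy group never stands alone on that ring in the compounds shown.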